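The source may report more compounds than this note shows. Statements on the series, on what has been measured and on what is new or still open speak of the compounds shown alone.

In a functional assay on HeLa cells (Homo sapiens) for inhibition, with a stated time of 72 h (on this read-out higher numbers stand for weaker inhibition and lower numbers for stronger inhibition), compound 1 `COc1ccccc1-c1ccc(CNc2nc(NC3CCC(N)CC3)nc3c2ncn3C2CCCC2)cc1` gives 333 nM, compound 2 `NC1CCC(Nc2nc(NCc3ccc(-c4ccco4)cc3)c3ncn(C4CCCC4)c3n2)CC1` gives 71 nM and compound 3 `NC1CCC(Nc2nc(NCc3ccc(-c4ccccc4O)cc3)c3ncn(C4CCCC4)c3n2)CC1` gives 4180 nM, so compound 2 holds the lowest of the three numbers. Compound 4 `NC1CCC(Nc2nc(NCc3cc(Cl)ccc3O)c3ncn(C4CCCC4)c3n2)CC1` differs from compound 2 in one place 5-chloro-2-hydroxyphenyl in place of 4-(furan-2-yl)phenyl on a saturated chain carbon bound to a nitrogen on an aromatic ring: 5-chloro-2-hydroxyphenyl stands in place of 4-(furan-2-yl)phenyl on a saturated chain carbon bound to a nitrogen on an aromatic ring. Among the measured compounds shown here, no measured step makes this exact change. The closest guide is a 59-fold higher number from compound 2 to compound 3 (1.77 log units; beyond the scatter), a large step that also brings in a hydroxyphenyl group. The step of a 13-fold higher number from compound 1 to compound 3 (1.10 log units; beyond the scatter) is also large, while a 4.7-fold lower number from compound 1 to compound 2 (0.67 log units; beyond the scatter) is modest. A large rise in this assay is therefore expected, and the expected step is a 35-fold higher number from compound 2 to compound 4 (1.55 log units; beyond the scatter). Compound 4 is estimated at 2500 nM, with an expected range of 400 nM to 15000 nM.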

Compound 4, half-maximal inhibitory concentration: 750 nM
The estimate for compound 4 lay 3.3-fold (0.52 log units) above the measured number; the range from low to high includes it.
By their numbers in this assay, from the lowest: compound 2; then compound 1; then compound 4; then compound 3.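

With 5-chloro-2-hydroxyphenyl on the saturated chain carbon bound to a nitrogen on an aromatic ring, this assay shows an 11-fold higher number from compound 2 to compound 4 (1.02 log units; beyond the scatter) as the step. Unlike the earlier compounds, whose groups here all hold two aromatic rings, compound 4 carries a single six-membered aromatic ring and still gives a measurable inhibition number of 750 nM in this assay. Nothing measured here accounts for this step. The compounds shown leave open what the chlorine and the hydroxyl each contribute, as they appear only together on this single ring. They also leave open whether an amine or a carboxylic acid in place of the chlorine would lower or raise the number.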